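Methylating the Ring Amine: Does the Loss Repeat?

The source may hold more compounds than are shown below. What is called first, only, known or untested is meant among the compounds shown, and "the series" means these compounds.

Of the compounds shown here, three have been tested in an in vitro functional assay on SH-EP1 cells for agonist activity at Neuronal acetylcholine receptor; alpha4/beta2 (Homo sapiens), read by FLIPR and calcium flux; a higher number here means a larger maximal response, a lower number a smaller maximal response. Compound 1 `C1=C(c2cccnc2)C[C@@H]2CNC[C@H]1C2` gives 131%. Compound 2 `CN1C[C@@H]2C=C(c3cccnc3)C[C@@H](C2)C1` carries a single change relative to compound 1, (methyl in place of hydrogen on an amine nitrogen in a ring), and in this assay compound 2 gives 17%. That change produced a step of a number 114 percentage points lower from compound 1 to compound 2 (beyond the scatter). Compound 3 `CC(C)Oc1cncc(C2=CC3CNCC(C2)C3)c1` is built on a different core; how its core differs from that of compound 1 is not broken down here. In this assay compound 3 gives 54%, which places it second of the three, beyond the scatter from compound 2 below it and from compound 1 above it.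

Compound 4 `CC(C)Oc1cncc(C2=CC3CC(C2)CN(C)C3)c1` has not yet been measured. It stands to compound 3 exactly as compound 2 stands to compound 1: methyl in place of hydrogen on an amine nitrogen in a ring. The place of the change is described in the same words for both pairs, so this is the same change applied to a second core. Because the first application gave a number 114 percentage points lower from compound 1 to compound 2 (beyond the scatter), a drop in the same direction is expected here, though compound 3 starts from the lower value 54%, so a drop of the same absolute size cannot repeat and a smaller one is expected instead. The expected step is a number 44 percentage points lower from compound 3 to compound 4 (beyond the scatter). Compound 4 is therefore estimated to give 10%, within a range from 0% to 30%.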

Compound 4, largest response reached (reported as percent of maximum), in percent of the reference or control that the assay uses: 3.3%
Compound 4: middle estimate off by 6.7 percentage points, on the high side, and the stated range covers the measured number.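

In this assay, putting methyl in place of hydrogen on an amine nitrogen in a ring again lowered the response, with a number 50.7 percentage points lower from compound 3 to compound 4 (beyond the scatter), so the direction of the change carried over from the core of compound 1 to the core of compound 3. The size of the step did not carry over, and the two steps differ by more than ordinary repeat-to-repeat variation would explain: the same change on two cores in this assay, a number 114 percentage points lower (beyond the scatter) from compound 1 to compound 2 and a number 50.7 percentage points lower (beyond the scatter) from compound 3 to compound 4, 63.3 percentage points apart, beyond the scatter of two such steps. This does not show that the methyl matters less on the second core: compound 3 gives only 54%, a number too small to allow a step as large as the first, and two cores cannot show why the sizes differ or set a rule for a third core.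

The compounds shown leave open whether a group larger than methyl on that nitrogen, such as ethyl or benzyl, would lower the response in the same way, and whether an acetyl group there, which would turn the amine into an amide, would do the same. They also leave open whether the same drop would appear on a third core whose unchanged compound gives a high response.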